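Side-chain aryl change from compound 3 to compound 4

A few compounds are considered here, and "the series" means these few. Any claim that something is new, unique, unknown or untested is made for them only; others in the source may bear on it.

In a functional assay on MCF7 cells (Homo sapiens) for inhibition, read by MTT assay, with a stated time of 3 days (on this read-out lower numbers stand for stronger inhibition and higher numbers for weaker inhibition), compound 1 `COc1ccc(COc2cc(/C=C\c3cc(OC)c(OC)c(OC)c3)ccc2OC)cc1` gives 48000 nM, compound 2 `COc1ccc(/C=C\c2cc(OC)c(OC)c(OC)c2)cc1OCc1ccc(Br)cc1` gives 29000 nM and compound 3 `COc1ccccc1/C=C/CCCOc1cc(/C=C\c2cc(OC)c(OC)c(OC)c2)ccc1OC` gives 21000 nM. Compound 3 shares the low end of this narrow range with compound 2: a 1.4-fold lower number from compound 2 to compound 3 (0.14 log units; within the scatter), while a 2.3-fold lower number from compound 1 to compound 3 (0.36 log units; beyond the scatter). Compound 4 `COCOc1cccc(/C=C/CCCOc2cc(/C=C\c3cc(OC)c(OC)c(OC)c3)ccc2OC)c1` differs from compound 3 by 3-(methoxymethoxy)phenyl in place of 2-methoxyphenyl on a double-bonded chain carbon bound to a double-bonded chain carbon, with 3-(methoxymethoxy)phenyl in place of 2-methoxyphenyl on a double-bonded chain carbon bound to a double-bonded chain carbon. Among the measured compounds shown here, no measured step makes this exchange. The closest evidence is the replacement of the larger group in a 2.3-fold lower number from compound 1 to compound 3 (0.36 log units; beyond the scatter) and a 1.4-fold lower number from compound 2 to compound 3 (0.14 log units; within the scatter), both small, so no step beyond the scatter is expected in this assay. The expected step is a 1.0-fold higher number from compound 3 to compound 4 (0.02 log units; within the scatter). The estimate for compound 4 is 22000 nM, with an expected range of 9000 nM to 50000 nM.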

Compound 4, half-maximal inhibitory concentration: 8000 nM
For compound 4 the middle estimate is 2.8-fold (0.44 log units) above the measured one; the whole stated range lies above it.
By their numbers in this assay, from the lowest: compound 4; then compounds 3, 2 and 1 (each within the scatter of the next, the first and the last beyond it).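

With the 4-arylbut-3-en-1-yl chain held constant, the aryl group at its end still affects the read-out in this assay: exchanging 2-methoxyphenyl for 3-(methoxymethoxy)phenyl gives a 2.6-fold lower number from compound 3 to compound 4 (0.42 log units; beyond the scatter). The earlier steps shown here changed the whole side chain, whereas this one changes only the aryl group on the double-bonded chain carbon. No available data bear on the reason for this step.

Among the compounds shown here, the single exchange alters both the substituent and its ring location, so the share of each stays open. From the compounds shown here alone, how a phenyl ring bearing a hydroxyl or an amine would read also stays open.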